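Swapping methoxy for nitro on compound 1

This account rests on a few compounds, and the source may have more. Where it says the series, first, only, none or still open, it means among the compounds named here.

Going by the values given here, in a functional assay on HepG2 cells (Homo sapiens) for inhibition, read by MTT assay, with a stated time of 72 h (a higher number here means a weaker inhibitor, a lower number a stronger inhibitor), compound 1 (`COc1ccc(/C=C/C(=O)c2c(OC)cc(O)c(CC=C(C)C)c2O)cc1`) gives 32400 nM as the only actual number so far. Compound 2 (`COc1cc(OC)c(OC)cc1/C=C/C(=O)c1c(OC)cc(O)c(CC=C(C)C)c1O`) stands at > 50000 nM which is a limit of this assay and not a number. Among the compounds with values here, compound 3 (`COc1cc(O)c(CC=C(C)C)c(O)c1C(=O)/C=C/c1ccc([N+](=O)[O-])cc1`) keeps the core of compound 1 and carries nitro in place of methoxy on an aromatic carbon, para to a large group (nitro in place of methoxy on an aromatic carbon) as its only change. Within the data shown here, no measured step covers this change, so the expected step of a 1.2-fold lower number from compound 1 to compound 3 (0.10 log units; within the scatter) stays within the usual scatter. The estimated value for compound 3 is 26000 nM with an expected range from 9000 nM to 50000 nM in this assay once measured.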

Compound 3, half-maximal inhibitory concentration: 12400 nM
For compound 3 the middle estimate is 2.1-fold (0.32 log units) above the measured one; the range from low to high includes it.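

Carrying nitro in place of methoxy on this aromatic carbon, para to a large group, gives a 2.6-fold lower number from compound 1 to compound 3 (0.42 log units; beyond the scatter) in this assay, the only measured step at this position. The position is therefore not indifferent to the group it carries, and with the core of compound 1 held fixed, 4-nitrophenyl gives the stronger inhibitor of this pair, though only modestly so. Going by these compounds, whether an amine or a carboxylic acid at this position would move the number further, and in which direction, stays open. Nothing shown gives a cause for this step.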